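Compound 3: 2-methylprop-1-en-1-yl replacing 1-chloroethenyl

A few compounds are considered here, and "the series" means these few. Any claim that something is new, unique, unknown or untested is made for them only; others in the source may bear on it.

In a functional assay on A549 cells (Homo sapiens) for inhibition, read by MTT assay, with a stated time of 72 h (on this read-out higher numbers stand for weaker inhibition and lower numbers for stronger inhibition), compound 1 `C=CC(=O)Nc1cc(Nc2nc3c(c(-c4cn(C)c5ccc(F)cc45)n2)CSCC3)c(OC)cc1N(C)CCN(C)C` gives 4550 nM and compound 2 `C=C(Cl)C(=O)Nc1cc(Nc2nc3c(c(-c4cn(C)c5ccc(F)cc45)n2)CSCC3)c(OC)cc1N(C)CCN(C)C` gives 864 nM (the lower of the two numbers). Compound 3 `COc1cc(N(C)CCN(C)C)c(NC(=O)C=C(C)C)cc1Nc1nc2c(c(-c3cn(C)c4ccc(F)cc34)n1)CSCC2` differs from compound 2 by 2-methylprop-1-en-1-yl in place of 1-chloroethenyl on a carbonyl carbon. Going by the values given here, only one measured step bears on this change: a 5.3-fold lower number from compound 1 to compound 2 (0.72 log units; beyond the scatter) on introducing the chloro. Among the compounds with values here, compound 3 has no chloro, so a move back toward higher numbers in this assay is expected, though the data hold no direct precedent for the added carbons. The expected change is a 3.2-fold higher number from compound 2 to compound 3 (0.51 log units; beyond the scatter) overall. For compound 3 the estimate is 2800 nM (expected range 1000 nM to 8000 nM).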

Compound 3, half-maximal inhibitory concentration: 902 nM
Estimate against measurement, compound 3: 3.1-fold (0.49 log units) above; measured number below the stated range.
By their numbers in this assay, from the lowest: compounds 2 and 3 (each within the scatter of the next); then compound 1.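

In this assay, the step of a 1.0-fold higher number from compound 2 to compound 3 (0.02 log units; within the scatter) puts 2-methylprop-1-en-1-yl and 1-chloroethenyl on a level at this carbonyl carbon. The step of a 5.0-fold lower number from compound 1 to compound 3 (0.70 log units; beyond the scatter) shows that the drop in the number relative to vinyl does not depend on the chloro, as a group with carbon atoms only gives a drop of similar size. Nothing measured here explains this. Open, as far as these compounds go, is whether a longer chain or a dimethylamine on the chain would hold this level, and whether a saturated propyl group would do so without the double bond.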